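Swapping the Aromatic Acyl Group for Acetyl

This account rests on a few compounds, and the source may have more. Where it says the series, first, only, none or still open, it means among the compounds named here.

Measured so far in a functional assay on HCT-15 cells (Homo sapiens) for cytotoxicity, read by sulforhodamine B assay, with a stated time of 72 h; on this read-out lower numbers stand for stronger inhibition of growth and higher numbers for weaker inhibition of growth:
Compound 1, `O=C(Nc1ccccc1)C1CCc2ccccc2N1`, gives 109000 nM.
Compound 2, `O=C(Nc1cc(C(F)(F)F)cc(C(F)(F)F)c1)C1CCc2ccccc2N1C(=O)c1ccc(Cl)cc1`, gives 2220 nM.
Compound 3, `O=C(Nc1ccccc1O)C1CCc2ccccc2N1`, gives 5610 nM.

Compound 2 has the lowest number of the three, with compound 3 nearest to it and compound 1 furthest away. For the measured compounds named here, the only single-point step measured, a 19-fold lower number from compound 1 to compound 3 (1.29 log units; beyond the scatter), concerns a hydroxy group on an aromatic ring and tells nothing about the group on the ring nitrogen. Compound 4, `CC(=O)N1c2ccccc2CCC1C(=O)Nc1cc(C(F)(F)F)cc(C(F)(F)F)c1`, differs from compound 2 by methyl in place of 4-chlorophenyl on a carbonyl carbon. Going by the values given here, no measured step bears on this change, so its direction is uncertain; a modest rise in the number is expected as a cautious guess. Compound 4 is expected to give 5000 nM, between 1500 nM and 20000 nM. That corresponds to an expected step of a 2.3-fold higher number from compound 2 to compound 4 (0.35 log units; beyond the scatter).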

Compound 4, concentration for 50% growth inhibition: > 70000 nM
Compound 4 ended at the assay's limit; the forecaster's own chance of this, stated with the estimate: 5%; middle value at least 14-fold (1.14 log units) away from the limit.
By their numbers in this assay, from the lowest: compound 2; then compound 3; then compound 1.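

Methyl in place of 4-chlorophenyl on a carbonyl carbon brings an at least 31-fold higher number from compound 2 to compound 4 (1.49 log units; beyond the scatter) and so shows that this group matters greatly here, which no earlier step could reveal. In this assay compound 4 gives > 70000 nM and that is a limit of the assay, not a number. Compound 2 and compound 4 differ in this one place only, so the loss of growth inhibition goes with this single change.

For the compounds shown here, only two groups are compared at this carbonyl carbon, so it stays open how a longer chain, a plain phenyl without chlorine, or a phenyl carrying an amine in place of the chlorine would fare.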